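The source may report more compounds than this note shows. Statements on the series, on what has been measured and on what is new or still open speak of the compounds shown alone.

Going by the values given here, in a physicochemical assay for inhibition, read by spectrophotometry, with a stated time of 10 min (on this read-out higher numbers stand for weaker inhibition and lower numbers for stronger inhibition), compound 1 `Nc1nc(N)c2cc(N(Cc3ccc(OC(F)(F)F)cc3)Cc3ccc(OC(F)(F)F)cc3)ccc2n1` gives 33900 nM as the highest of the two numbers so far. Compound 2 `COc1ccc(CNc2ccc3nc(N)nc(N)c3c2)cc1` gives 5720 nM in the same read-out. The gap between these two numbers lies beyond the scatter. Among the compounds with values here, compound 3 `COc1ccc(CN(Cc2ccc(OC(F)(F)F)cc2)c2ccc3nc(N)nc(N)c3c2)cc1` has methyl in place of trifluoromethyl on an oxygen on an aromatic ring as its one change from compound 1. Within the data shown here, no measured step covers this change, so any expectation is loose. A moderate move toward lower numbers in this assay is expected, with a 2.3-fold lower number from compound 1 to compound 3 (0.35 log units; beyond the scatter) as the estimated step. For compound 3 the estimated value is 15000 nM within an expected range of 5000 nM to 40000 nM for now.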

Compound 3, half-maximal inhibitory concentration: 24500 nM
Estimate against measurement, compound 3: 1.6-fold (0.21 log units) below; measured number inside the range.
By their numbers in this assay, from the lowest: compound 2; then compounds 3 and 1 (each within the scatter of the next).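

In this assay, methyl in place of trifluoromethyl on an oxygen on an aromatic ring gives a 1.4-fold lower number from compound 1 to compound 3 (0.14 log units; within the scatter), so this read-out does not separate trifluoromethoxy from methoxy at this place, with the other 4-(trifluoromethoxy)benzyl kept in compound 3. No evidence at hand bears on this result. Open, from the compounds shown here alone, is whether a longer chain such as ethyl on the same oxygen, or an amine in place of the methoxy, would move the number beyond the scatter. Also open, going by these compounds, is whether methoxy in place of the remaining trifluoromethoxy would do so.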